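The source may hold more compounds than are shown below. What is called first, only, known or untested is meant among the compounds shown, and "the series" means these compounds.

Measured compounds:
Compound 1 `COc1cc(-c2nn(-c3cccc(NC(=O)Nc4ccc(Cl)c(C(F)(F)F)c4)c3)cc2-c2ccncc2)ccc1Cl` — 5010 nM
Compound 2 `COc1cc(-c2nn(-c3cccc(NC(=O)c4ccccc4)c3)cc2-c2ccncc2)ccc1Cl` — > 100000 nM (a limit)

In a functional assay on SK-MEL-28 cells (Homo sapiens) for inhibition, read by sulforhodamine B assay, with a stated time of 48 h (on this read-out higher numbers stand for weaker inhibition of growth and lower numbers for stronger inhibition of growth), compound 1 gives 5010 nM. Compound 2 gives only a limit in this assay, > 100000 nM. Compound 1 therefore holds the only actual number shown, the other value being (the limit of > 100000 nM in this assay, at which 1 of the 2 values shown sits). Within the data shown here, the one measured step, an at least 19-fold higher number from compound 1 to compound 2 (1.30 log units; beyond the scatter), is large. Compound 3 `O=C(Nc1cccc(-n2cc(-c3ccncc3)c(-c3ccc(Cl)c(O)c3)n2)c1)Nc1ccc(Cl)c(C(F)(F)F)c1` differs from compound 1 by hydrogen in place of methyl on an oxygen on an aromatic ring. Among the measured compounds shown here, no measured step touches this change, since the known step alters a different part of the molecule. No step beyond the scatter is therefore expected, and compound 3 is estimated at 5000 nM, within 1500 nM to 17000 nM, a step of a 1.0-fold lower number from compound 1 to compound 3 (0.00 log units; within the scatter).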

Compound 3, concentration for total growth inhibition: 3330 nM
For compound 3 the middle estimate is 1.5-fold (0.18 log units) above the measured one, and the stated range covers the measured number.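

In this assay, replacing methoxy with hydroxy gives a 1.5-fold lower number from compound 1 to compound 3 (0.18 log units; within the scatter) and so separates the two compounds by no real margin. The earlier step concerned a different part of the molecule, whereas this pair shows that the methyl on this oxygen can be removed without a difference beyond the scatter. Nothing measured here gives a reason for this result. Going by these compounds, whether a longer chain on this oxygen, such as ethoxy, would behave the same stays open. So does whether an amine in place of the hydroxy would.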